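Methyl on the fused core and cell growth inhibition

The source may report more compounds than this note shows. Statements on the series, on what has been measured and on what is new or still open speak of the compounds shown alone.

Compound 1 `COc1cc(/C=C/C(=O)/C=C/c2nc3c(C)cccc3n2C)ccc1O` and compound 2 `COc1cc(/C=C/C(=O)/C=C/c2nc3c(C)c(C)ccc3n2C)ccc1O` share one core; compound 2 differs by methyl in place of hydrogen on an aromatic carbon. In a functional assay on NCI-H460 cells (Homo sapiens) for cytotoxicity, read by MTT assay, with a stated time of 48 h (on this read-out higher numbers stand for weaker inhibition and lower numbers for stronger inhibition), compound 1 gives 3000 nM, and compound 2 gives 31900 nM; the step is an 11-fold higher number from compound 1 to compound 2 (1.03 log units; beyond the scatter). Compound 3 `COc1ccc(/C=C/C(=O)/C=C/c2nc3ccccc3n2C)cc1O` has a different core; the difference between its core and the core of compound 1 is not broken down here. In this assay compound 3 gives 6900 nM, a higher number than compound 1 and a lower number than compound 2. Compound 4 `COc1ccc(/C=C/C(=O)/C=C/c2nc3c(C)cccc3n2C)cc1O`, not yet measured, differs from compound 3 by methyl in place of hydrogen on an aromatic carbon. This is the same kind of change as from compound 1 to compound 2, not the same: there the entering methyl sat ortho to a methyl group, meta to a fused ring and para to a fused ring, whereas here it sits ortho to a fused ring and meta to a fused ring. Among the measured compounds shown here, because an 11-fold higher number from compound 1 to compound 2 (1.03 log units; beyond the scatter) ran toward a higher number, some weakening is possible, but the differing place gives no direct precedent, so only a small step of a 1.2-fold lower number from compound 3 to compound 4 (0.06 log units; within the scatter) is expected. Compound 4 is expected to give 6000 nM in this assay, from 2500 nM to 15000 nM.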

Compound 4, half-maximal inhibitory concentration: 25400 nM
For compound 4 the middle estimate is 4.2-fold (0.63 log units) below the measured one, outside the stated range (above it).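

In this assay, methyl in place of hydrogen on an aromatic carbon again moves the read-out the same way, with a 3.7-fold higher number from compound 3 to compound 4 (0.57 log units; beyond the scatter), so the direction of the change holds on both cores shown. Its size does not carry over from one core to the other: the same change on two cores in this assay, an 11-fold higher number (1.03 log units; beyond the scatter) from compound 1 to compound 2 and a 3.7-fold higher number (0.57 log units; beyond the scatter) from compound 3 to compound 4, 2.9-fold (0.46 log units) apart, beyond the scatter of two such steps With only two steps, and with the entering methyl in a different place on each core, these data cannot separate an influence of the core from an influence of the place, and they give no rule beyond the compounds shown.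

Going by these compounds, it remains open whether methyl at the place used in the step from compound 1 to compound 2 would, on the core of compound 3, give a step of that size. On these data alone, it also remains open whether a group other than methyl on the aromatic carbon changed in compound 4, such as chlorine, an amine or a carboxylic acid, would move the number in the same direction.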